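Cyclopropyl for pentyl on the shared core

The compounds below may be only part of what the source reports. "The series", "measured", "known", "first", "only" and "open" are said of these compounds alone.

In a functional assay on MCF7 cells (Homo sapiens) for inhibition, read by fluorescence, with a stated time of 72 h (on this read-out lower numbers stand for stronger inhibition of growth and higher numbers for weaker inhibition of growth), compound 1 `c1ccc(-n2cc3cnc(-c4ccsc4)cc3n2)cc1` gives 9800 nM, compound 2 `CCCCc1cc2nn(-c3ccccc3)cc2cn1` gives 13300 nM and compound 3 `CCCCCc1cc2nn(-c3ccccc3)cc2cn1` gives 11800 nM. Compound 3 stands second highest of the three numbers, but a 1.1-fold lower number from compound 2 to compound 3 (0.05 log units; within the scatter) and a 1.2-fold higher number from compound 1 to compound 3 (0.08 log units; within the scatter) are both within the scatter. Compound 4 `c1ccc(-n2cc3cnc(C4CC4)cc3n2)cc1` differs from compound 3 by cyclopropyl in place of pentyl on an aromatic carbon. For the measured compounds named here, the steps that bear on this exchange are a 1.4-fold higher number from compound 1 to compound 2 (0.13 log units; within the scatter), a 1.2-fold higher number from compound 1 to compound 3 (0.08 log units; within the scatter) and a 1.1-fold lower number from compound 2 to compound 3 (0.05 log units; within the scatter): each earlier exchange at this aromatic carbon, whether thiophen-3-yl, butyl or pentyl, stayed within the scatter in this assay. For compound 4 no step beyond the scatter is therefore expected, a 1.0-fold lower number from compound 3 to compound 4 (0.01 log units; within the scatter). Compound 4 is expected to give 11500 nM, in an estimated range from 5000 nM to 26000 nM.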

Compound 4, concentration for 50% growth inhibition: 69300 nM
Compound 4: middle estimate off by 6.0-fold (0.78 log units), on the low side; measured number above the stated range.
By their numbers in this assay, from the lowest: compounds 1, 3 and 2 (each within the scatter of the next); then compound 4.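

At this aromatic carbon in this assay, the position does not treat all carbon groups alike: against pentyl there is a 5.9-fold higher number from compound 3 to compound 4 (0.77 log units; beyond the scatter) while against butyl there is a 5.2-fold higher number from compound 2 to compound 4 (0.72 log units; beyond the scatter) and against thiophen-3-yl there is a 7.1-fold higher number from compound 1 to compound 4 (0.85 log units; beyond the scatter) in this series. Cyclopropyl alone separates from the other three groups, which remain within the scatter of one another. No measurement shown accounts for this separation. Going by these compounds, whether a propyl chain would stay with butyl and pentyl or fall with cyclopropyl remains open. A cyclobutyl or cyclopentyl group would test whether the separation extends to other saturated rings.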